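The source may hold more compounds than are shown below. What is called first, only, known or untested is meant among the compounds shown, and "the series" means these compounds.

Measured compounds:
compound 1, `COc1cc(C(c2ccc(O)c(OC)c2)[C@@H](C)[C@H](C)CO)ccc1O`, in a functional assay on HeLa cells (Homo sapiens) for cytotoxicity, read by WST assay, with a stated time of 48 h; a lower number here means a stronger inhibitor, a higher number a weaker inhibitor: > 100000 nM
compound 2, `COc1cc(C(c2ccc(O)c(OC)c2)[C@H](C)[C@H](C)CF)ccc1O`, in this assay: 75000 nM
compound 3, `COc1cc(C(c2ccc(O)c(OC)c2)[C@@H](C)[C@H](C)CF)ccc1O`, in this assay: 37000 nM

Compound 1 gives only a limit in this assay, not a number, so it is the weakest point of reference here. Compound 4, `COC[C@H](C)[C@@H](C)C(c1ccc(O)c(OC)c1)c1ccc(O)c(OC)c1`, has not yet been measured. It differs from compound 1 in this way: 2-(methoxymethyl)-1-methylpropyl in place of 2-(hydroxymethyl)-1-methylpropyl on a saturated chain carbon bound to two aromatic carbons. Among the measured compounds shown here, two measured steps bear on this, both replacing the hydroxy group with something that carries no hydrogen-bond donor: an at least 1.3-fold lower number from compound 1 to compound 2 (0.12 log units; that floor lies within the scatter) and an at least 2.7-fold lower number from compound 1 to compound 3 (0.43 log units; beyond the scatter). The first stays within the scatter, the second lies beyond it, and the gap between compounds 2 and 3 is itself a 2.0-fold lower number from compound 2 to compound 3 (0.31 log units; beyond the scatter) because of the fact that compounds 2 and 3 differ only in the configuration as drawn. Since the starting point is a limit (the limit of > 100000 nM in this assay, at which 1 of the 3 values shown sits), the true size of either step is uncertain. A similar modest lowering of the number is therefore expected for compound 4, an at least 1.6-fold lower number from compound 1 to compound 4 (0.22 log units; that floor lies within the scatter), though it may also stay at the limit. The estimate for compound 4 in this assay is 60000 nM, between 25000 nM and 150000 nM.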

Compound 4, half-maximal inhibitory concentration: 77000 nM
Compound 4: middle estimate off by 1.3-fold (0.11 log units), on the low side, within the range that was stated.
By their numbers in this assay, from the lowest: compound 3; then compounds 2 and 4 (each within the scatter of the next). At a limit, above all of these: compound 1.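

Methoxymethyl in place of hydroxymethyl gives an at least 1.2-fold lower number from compound 1 to compound 4 (0.11 log units; that floor lies within the scatter), but this is only a floor, and the starting value is a limit: the limit of > 100000 nM in this assay, at which 1 of the 4 values shown sits. The clearer new reading is that 1-(methoxymethyl)ethyl in place of 1-(fluoromethyl)ethyl gives a 1.0-fold higher number from compound 2 to compound 4 (0.01 log units; within the scatter), so these two groups read alike at this place in this assay. The other new step, a 2.1-fold higher number from compound 3 to compound 4 (0.32 log units; beyond the scatter), replaces the whole 2-(fluoromethyl)-1-methylpropyl group, its configuration as drawn included, so it cannot be credited to the methoxy end alone.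

As far as these compounds go, it remains open whether a methoxymethyl chain drawn in the configuration of compound 3 would match compound 3. From the compounds shown here alone, it is also open whether a chain ending in an amine or a carboxylic acid, or a longer chain, would move the number further.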